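A few compounds are considered here, and "the series" means these few. Any claim that something is new, unique, unknown or untested is made for them only; others in the source may bear on it.

Measured in a functional assay on A549 cells (Homo sapiens) for cytotoxicity, read by MTT assay, with a stated time of 48 h; a higher number here means a weaker inhibitor, a lower number a stronger inhibitor:
- Compound 1 `C=C1C(=O)O[C@H]2CC3=C[C@H](C/C(C)=C/[C@@H](OC(=O)c4ccc(C(F)(F)F)cc4)[C@H]12)OC3=O`: > 10000 nM, a limit and not a number
- Compound 2 `C=C1C(=O)O[C@H]2CC3=C[C@H](C/C(C)=C/[C@@H](OC(=O)c4ccc([N+](=O)[O-])cc4)[C@H]12)OC3=O`: > 10000 nM, a limit and not a number
- Compound 3 `C=C1C(=O)O[C@H]2CC3=C[C@H](C/C(C)=C/[C@@H](OC(=O)/C=C/c4ccccc4)[C@H]12)OC3=O`: 4800 nM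

Compound 3 is the only one of the three with an actual number, 4800 nM. Compounds 1 and 2 both rest on (the limit of > 10000 nM in this assay, at which 2 of the 3 values shown sit).

Compound 4 `C=C1C(=O)O[C@H]2CC3=C[C@H](C/C(C)=C/[C@@H](OC(=O)/C=C/c4ccc(C(F)(F)F)cc4)[C@H]12)OC3=O` differs from compound 3 in one place: trifluoromethyl in place of hydrogen on an aromatic carbon. Put simply, trifluoromethyl stands in place of hydrogen on an aromatic carbon, para to a large group, turning phenyl into 4-(trifluoromethyl)phenyl.

For the measured compounds named here, no measured step makes this exact change. The closest evidence concerns the group on the carbonyl carbon: an at least 2.0-fold lower number from compound 1 to compound 3 (0.31 log units; beyond the scatter), and an at least 2.0-fold lower number from compound 2 to compound 3 (0.31 log units; beyond the scatter). Both steps bring in 2-phenylethenyl, and compound 4 keeps that link. Compound 1 does carry trifluoromethyl on its ring, but its ring sits directly on the carbonyl carbon. The swap of trifluoromethyl for nitro tells little, as it is a step that the two limits leave unreadable from compound 1 to compound 2.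

With so little to go on, no clear shift is expected in this assay. The expected result is a 1.1-fold higher number from compound 3 to compound 4 (0.06 log units; within the scatter). For compound 4 the estimated value is 5500 nM, with an expected range of 2000 nM to 13000 nM.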

Compound 4, half-maximal inhibitory concentration: 5900 nM
Estimate against measurement, compound 4: 1.1-fold (0.03 log units) below; low and high end bracket the measured number.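

Putting trifluoromethyl in place of hydrogen on this aromatic carbon, para to a large group, gives a 1.2-fold higher number from compound 3 to compound 4 (0.09 log units; within the scatter) in this assay, so this position carries the added group with no shift that can be read in this assay. Compound 1 also holds trifluoromethyl, but with its aromatic ring directly on the carbonyl carbon, and its > 10000 nM is a limit and not a number. Compound 4 keeps the 2-phenylethenyl link and, like compound 3, gives an actual number, whereas the two compounds without that link rest on a single limit: the limit of > 10000 nM in this assay, at which 2 of the 4 values shown sit.

The step between the two compounds at that limit cannot be read, so the comparison of trifluoromethyl with nitro on the directly attached ring stays closed. Going by these compounds, with only trifluoromethyl tested on this aromatic carbon of the 2-phenylethenyl series, it remains open whether a very different group there, such as an amine or a carboxylic acid, would also leave the number within the scatter of compound 3.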